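The source may report more compounds than this note shows. Statements on the series, on what has been measured and on what is new or still open speak of the compounds shown alone.

Measured compounds:
compound 1 `COc1ccc(N2C(=O)COc3ccc(-c4cnc5ccccc5c4)cc32)cc1` — > 40000 nM
compound 2 `O=C1COc2ccc(-c3cccc(NS(=O)(=O)c4ccc(F)cc4)c3)cc2N1` — > 40000 nM

Both measured compounds were tested in a functional assay on HeLa cells (Homo sapiens) for antiproliferative activity, read by MTT assay, with a stated time of 72 h; on this read-out lower numbers stand for stronger inhibition and higher numbers for weaker inhibition. Compound 1 gives > 40000 nM in this assay, which is a limit of the assay and not a number. Compound 2 gives > 40000 nM in this assay, and that too is only a limit. Compound 1 thus stands at the limit of > 40000 nM in this assay, at which 2 of the 2 values shown sit, and nothing shown separates it from compound 2. Compound 3 `O=C1COc2ccc(-c3cnc4ccccc4c3)cc2N1c1ccc(F)cc1` has not yet been measured in this assay. It differs from compound 1 by fluoro in place of methoxy on an aromatic carbon. Among the measured compounds shown here, no step between two measured compounds is at hand, so the only guide is that every value shown is a limit. The expected step in this assay is a number no higher from compound 1 to compound 3 (the limit leaves the size open), which is none beyond the scatter. For compound 3 the expected half-maximal inhibitory concentration is 40000 nM, in the range 10000 nM to 160000 nM, most likely reported as another limit.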

Compound 3, half-maximal inhibitory concentration: 38800 nM
Compound 3: middle estimate off by 1.0-fold (0.01 log units), on the high side; low and high end bracket the measured number.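

In this assay, among the compounds shown here, compound 3 gives 38800 nM, the first value here that is a number and not a limit, so this position on the 4-fluorophenyl group can now be placed on the scale. Compound 1 gives > 40000 nM, which is a limit of the assay and not a number. The change of methoxy to fluoro on this aromatic carbon, para to a large group, gives an at least 1.0-fold lower number from compound 1 to compound 3 (0.01 log units; that floor lies within the scatter), so nothing printed shows a change beyond the scatter, and most values still sit at one limit: the limit of > 40000 nM in this assay, at which 2 of the 3 values shown sit.

Going by these compounds, how far compound 1 lies past its limit stays open, and with it the true size of this step. Also open, on these data alone, is what an amine or a carboxylic acid on the same aromatic carbon would give in this assay.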